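Replacing a Branched Alkylamine Substituent With an Imidazolylmethyl Group

The source may report more compounds than this note shows. Statements on the series, on what has been measured and on what is new or still open speak of the compounds shown alone.

The compounds measured so far in a toxicity assay on A549 cells (Homo sapiens) for cytotoxicity, read by luminescence and CellTiter-Glo, with a stated time of 48 h; a lower number here means that less compound is tolerated, a higher number that more compound is tolerated:

Compound 1 `CCCCOc1ccc(-c2nc3ncccn3c2NC(C)(C)CC(C)(C)C)cc1` gives 29000 nM.
Compound 2 `CCCCOc1ccc(-c2nc3ncccn3c2NCC2CC2)cc1` gives > 100000 nM, which is a limit of the assay and not a number.
Compound 3 `CCCCOc1ccc(-c2nc3ncccn3c2Nc2ccccc2)cc1` gives 100000 nM.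

Compound 1 stands lowest of the two numbers; its nearest neighbour is compound 3, with a 3.4-fold higher number from compound 1 to compound 3 (0.54 log units; beyond the scatter). Compound 2 sits at the limit of > 100000 nM in this assay, at which 1 of the 3 values shown sits, so its distance from compound 1 is only bounded: an at least 3.4-fold higher number from compound 1 to compound 2 (0.53 log units; beyond the scatter). Between compound 2 and compound 3 the step reads a number no higher from compound 2 to compound 3 (the limit leaves the size open).

Compound 4 `CCCCOc1ccc(-c2nc3ncccn3c2NCc2c[nH]cn2)cc1` differs from compound 1 in the same place: (1H-imidazol-4-yl)methyl in place of 1,1,3,3-tetramethylbutyl on a nitrogen on an aromatic ring.

Both measured steps that bear on this change leave 1,1,3,3-tetramethylbutyl on the nitrogen on the aromatic ring, and both gave a higher number in this assay, one modest and one at least modest. Compound 4 is therefore expected to follow the same direction, with a step of about a 2.8-fold higher number from compound 1 to compound 4 (0.44 log units; beyond the scatter), so that more compound is tolerated than with compound 1. The estimate for compound 4 in this assay is 80000 nM, with a range from 30000 nM to 150000 nM.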

Compound 4, half-maximal cytotoxic concentration: > 100000 nM
Compound 4: a limit, no number; the forecaster's own chance of this, stated with the estimate: 40%; middle value at least 1.2-fold (0.09 log units) from the limit.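

In this assay compound 4 gives > 100000 nM, which is a limit of the assay and not a number. On the nitrogen on the aromatic ring, (1H-imidazol-4-yl)methyl thus joins cyclopropylmethyl and phenyl as a third replacement for 1,1,3,3-tetramethylbutyl that gives a higher number, with an at least 3.4-fold higher number from compound 1 to compound 4 (0.53 log units; beyond the scatter), and compound 1 remains the lowest of the compounds shown, now also with a five-membered aromatic ring with 2 hetero atoms among the groups compared. Against compound 3 the result gives only a direction, a number no lower from compound 3 to compound 4 (the limit leaves the size open), and the step between compound 2 and compound 4 cannot be read, so the three replacements cannot be ranked against each other, and the ceiling now holds more of the series: the limit of > 100000 nM in this assay, at which 2 of the 4 values shown sit.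

The compounds shown leave open how much compound 2 and compound 4 are really tolerated, as neither has a number. They also leave open whether a tert-butyl group or a straight octyl chain on the same nitrogen would bring the number back towards that of compound 1, or whether 1,1,3,3-tetramethylbutyl stands alone in this.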